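Benzoyl to acetyl on the sulfonyl-bearing alkene of compound 3

The source may report more compounds than this note shows. Statements on the series, on what has been measured and on what is new or still open speak of the compounds shown alone.

Measured compounds:
compound 1 `N#C/C(=C\c1c(-c2ccccc2)[nH]c2ccccc12)C(=O)c1ccccc1`: 10000 nM
compound 2 `CCOC(=O)C(=Cc1c(-c2ccccc2)[nH]c2ccccc12)C(=O)OCC`: 12400 nM
compound 3 `O=C(/C(=C\c1c(-c2ccccc2)[nH]c2ccccc12)S(=O)(=O)c1ccccc1)c1ccccc1`: 4600 nM

In a functional assay on EKVX cells (Homo sapiens) for inhibition, read by sulforhodamine B assay, with a stated time of 48 h (on this read-out lower numbers stand for stronger inhibition of growth and higher numbers for weaker inhibition of growth), compound 3 gives 4600 nM, the lowest of the three numbers. Compound 1 gives 10000 nM and compound 2 gives 12400 nM; both gaps to compound 3 lie beyond the scatter, so compound 3 is the most potent of the three in this assay.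

Compound 4 `CC(=O)/C(=C\c1c(-c2ccccc2)[nH]c2ccccc12)S(=O)(=O)c1ccccc1` differs from compound 3 in one place: methyl in place of phenyl on a carbonyl carbon. Within the data shown here, no measured pair shows this change, so its size is not known from the data.

The step is expected to be small, no larger than the scatter, with a slight loss of potency as the more likely direction: a 1.4-fold higher number from compound 3 to compound 4 (0.15 log units; within the scatter). Compound 4 is therefore expected to give about 6500 nM in this assay, within a range of 2500 nM to 16000 nM.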

Compound 4, concentration for 50% growth inhibition: 3300 nM
Compound 4: the middle estimate sits 2.0-fold (0.29 log units) above what was measured; low and high end bracket the measured number.
By their numbers in this assay, from the lowest: compounds 4 and 3 (each within the scatter of the next); then compounds 1 and 2 (each within the scatter of the next).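

Methyl in place of phenyl on a carbonyl carbon gives a 1.4-fold lower number from compound 3 to compound 4 (0.14 log units; within the scatter) in this assay and so leaves the number at this level. At this place, the phenyl of the benzoyl group can therefore be lost without a loss of growth inhibition, and one carbon serves as well as six. Nothing on hand accounts for this tolerance.

Still open, on these data alone, is how this carbonyl carbon responds to a longer chain, an amine or a hydroxyl in place of methyl. Also open, as far as these compounds go, is whether benzoyl to acetyl behaves the same way on compound 1, which carries a nitrile instead of the sulfonyl group.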